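Swapping an Aromatic Ring for a Small Branched Chain

The source may report more compounds than this note shows. Statements on the series, on what has been measured and on what is new or still open speak of the compounds shown alone.

Of the compounds shown here, two sharing one core have been measured in an in vitro functional assay on cells for agonist activity at Bombesin receptor subtype-3 (Mus musculus), read by luminescence and calcium flux; a higher number here means that more compound is needed for the effect, a lower number that less compound is needed. Compound 1 `O=C(O)c1ccccc1-c1ccc(CCc2ncc(Cc3ccccc3Cl)[nH]2)cc1` gives 22 nM in this assay. Within the data shown here, compound 2 `N#Cc1ccc(Cc2cnc(CCc3ccc(-c4ccccc4C(=O)O)cc3)[nH]2)cc1`, which carries a 4-cyanophenyl group on a saturated chain carbon bound to an aromatic carbon, gives 723 nM in this assay, the higher of the two numbers; the only step available, a 33-fold higher number from compound 1 to compound 2 (1.52 log units; beyond the scatter), shows how much the group at this position matters.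

Compound 3 `CC(C)(C)Cc1cnc(CCc2ccc(-c3ccccc3C(=O)O)cc2)[nH]1` is not yet measured. Relative to compound 2 the change is tert-butyl in place of 4-cyanophenyl on a saturated chain carbon bound to an aromatic carbon. Among the measured compounds shown here, no measured step involves a group without a ring at this position, so the step from compound 1 to compound 2 bears on it only indirectly, by showing that this position is sensitive and that a change there can move the number by a large amount in either direction.

The expectation is therefore uncertain: compound 3 is estimated at 500 nM in this assay, within a range of 80 nM to 3000 nM. This estimate corresponds to an expected step of a 1.4-fold lower number from compound 2 to compound 3 (0.16 log units; within the scatter).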

Compound 3, half-maximal effective concentration: 6.3 nM
Estimate against measurement, compound 3: 79-fold (1.90 log units) above; the measured number lies below the stated range.
By their numbers in this assay, from the lowest: compound 3; then compound 1; then compound 2.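

The aromatic ring is not needed at this position: on a saturated chain carbon bound to an aromatic carbon, tert-butyl, with no ring and only 4 heavy atoms, gives a 110-fold lower number from compound 2 to compound 3 (2.06 log units; beyond the scatter) in this assay. It also improves on the better of the two ring-bearing compounds, with a 3.5-fold lower number from compound 1 to compound 3 (0.54 log units; beyond the scatter), so compound 3 has the lowest number of the three, and the earlier finding that this position is sensitive now extends to a group of a different kind. Nothing available here explains why the small branched chain outperforms both aromatic groups.

On these data alone, the case for a chain without a ring rests on tert-butyl alone, so it remains open whether isopropyl, a longer chain such as n-pentyl, or a saturated ring such as cyclohexyl would behave in the same way. As far as these compounds go, it is also open whether a chain carrying an amine or a hydroxyl group would keep a low number in this assay, or whether only chains made of carbon alone would do so.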